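The source may report more compounds than this note shows. Statements on the series, on what has been measured and on what is new or still open speak of the compounds shown alone.

Of the compounds shown here, two sharing the same core have been tested in a functional assay on SUP-B15 cells (Homo sapiens) for antiproliferative activity, with a stated time of 72 h; a higher number here means that more compound is needed for the effect, a lower number that less compound is needed. Compound 1 `COC(=O)c1cc(=O)c2c(OC)cc(OC)cc2n1S(=O)(=O)c1ccc(C)cc1` gives 9700 nM. Compound 2 `COc1ccc(-c2cc(=O)c3c(OC)cc(OC)cc3n2S(=O)(=O)c2ccc(C=O)cc2)cc1` gives only a limit of the assay, > 34400 nM, so its true value is not known as a number. For the measured compounds named here, the limit of > 34400 nM in this assay, at which 1 of the 2 values shown sits, is all that this assay reports for compound 2, and compound 1 therefore shows the only measured number here.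

Compound 3 `COc1ccc(-c2cc(=O)c3c(OC)cc(OC)cc3n2S(=O)(=O)c2ccc(Br)cc2)cc1` is the next step from compound 2: bromo in place of formyl on an aromatic carbon. Going by the values given here, no measured pair in this set shows what such a change does in this assay, so the size of the step from compound 2 to compound 3 rests on expectation alone. With compound 2 sitting at the limit, the step expected is an at least 1.0-fold lower number from compound 2 to compound 3 (0.00 log units; that floor lies within the scatter), no more than the usual scatter in either direction. Compound 3 is therefore estimated at 34000 nM, within a range from 12000 nM to 100000 nM.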

Compound 3, half-maximal effective concentration: 63800 nM
Estimate against measurement, compound 3: 1.9-fold (0.27 log units) below; measured number inside the range.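

Compound 2 has only a limit and compound 3 has a number, so no step from compound 2 to compound 3 can be read in this assay because the true value of compound 2 stays unknown: the limit of > 34400 nM in this assay, at which 1 of the 3 values shown sits.

The compounds shown leave open how large a change bromo in place of formyl on an aromatic carbon brings in this assay.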